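The source may report more compounds than this note shows. Statements on the series, on what has been measured and on what is new or still open speak of the compounds shown alone.

Compound 1, `O=C(CSc1nnc(-c2ccncc2)s1)Nc1ccc(Cl)cc1`, in an ADME assay on HepG2 cells (Homo sapiens) for cytotoxicity, with a stated time of 3 days (a higher number here means that more compound is tolerated, a lower number that less compound is tolerated), gives > 50000 nM, which is a limit of the assay and not a number.
Compound 2, `CC(CSc1nnc(-c2ccncc2)s1)C(=O)NCc1ccccc1Cl`, gives > 50000 nM in this assay, again a limit.
Compound 3, `CC(Sc1nnc(-c2ccncc2)s1)C(=O)Nc1ccc(Cl)cc1`, gives > 50000 nM in this assay, also a limit.

All three measured compounds therefore sit at the same place: the limit of > 50000 nM in this assay, at which 3 of the 3 values shown sit. Compound 1 is not placed by a number at all, only by this limit, and the same holds for compounds 2 and 3. Going by the values given here, the one measured step that changes a single place, a step that the two limits leave unreadable from compound 1 to compound 3, is a step between two limits and its size cannot be read. Compounds 2 and 3 differ in more than one place, and their two values show only that both lie at the limit.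

Compound 4, `O=C(CSc1nnc(-c2ccncc2)s1)NCc1ccccc1`, is not yet measured in this assay. It differs from compound 1 in one place: benzyl in place of 4-chlorophenyl on an amide-type nitrogen. Among the compounds with values here, no measured step bears directly on this change; the only single-place step, from compound 1 to compound 3, is unreadable, so no direction or size can be taken from it. Since every measured value, including that of compound 1 at the limit of > 50000 nM in this assay, at which 3 of the 3 values shown sit, is a limit, compound 4 is expected to sit at the limit too. Compound 4 is estimated at 50000 nM, with a range from 20000 nM to 100000 nM, and the expected step from compound 1 is a number no higher from compound 1 to compound 4 (the limit leaves the size open).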

Compound 4, half-maximal cytotoxic concentration: 17700 nM
Compound 4: middle estimate off by 2.8-fold (0.45 log units), on the high side, and the stated range ends above it.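

In this assay, benzyl in place of 4-chlorophenyl on the amide-type nitrogen gives an at least 2.8-fold lower number from compound 1 to compound 4 (0.45 log units; beyond the scatter), which makes this position the first place in the series where a single change brings the read-out down to a number, towards less compound tolerated. Compound 1 gives > 50000 nM, which is a limit and not a number, so the step may be larger than the size printed with it. The earlier compounds could not show this, as the one single-place step among them cannot be read and their values offer no number to compare: the limit of > 50000 nM in this assay, at which 3 of the 4 values shown sit.

From the compounds shown here alone, what part of the step falls to the chlorine that leaves and what part to the benzyl that enters stays open, since both change in this one step. Also open, going by these compounds, is how a plain phenyl, a phenethyl or a pyridylmethyl on the same nitrogen would stand in this assay.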